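Swapping the Outer Ring of the Shared Core

The source may report more compounds than this note shows. Statements on the series, on what has been measured and on what is new or still open speak of the compounds shown alone.

Of the compounds shown here, three sharing one core have been measured in a functional assay on DU-145 cells (Homo sapiens) for inhibition, read by trypan blue exclusion, with a stated time of 96 h; a lower number here means a stronger inhibitor of growth, a higher number a weaker inhibitor of growth. Compound 1 `O=C(/C(=C\c1ccc(F)cc1F)Sc1ccc(Br)cc1)c1ccc(Br)cc1` gives 1000 nM and compound 2 `O=C(/C(=C\c1ccc(Br)c([N+](=O)[O-])c1)Sc1ccc(Br)cc1)c1ccc(Br)cc1` gives 1000 nM. Compound 3 `COc1cc(/C=C(/Sc2ccc(Br)cc2)C(=O)c2ccc(Br)cc2)ccc1F` gives 10000 nM, the highest number of the three and therefore the weakest growth inhibitor here, its step from compound 1 being a 10-fold higher number from compound 1 to compound 3 (1.00 log units; beyond the scatter). Compound 4 `O=C(/C(=C\c1ccc(Br)c(O)c1)Sc1ccc(Br)cc1)c1ccc(Br)cc1` is not yet measured; it differs from compound 3 by 4-bromo-3-hydroxyphenyl in place of 4-fluoro-3-methoxyphenyl on a double-bonded chain carbon bound to a double-bonded chain carbon. For the measured compounds named here, the one measured step that touches this place is a 10-fold higher number from compound 1 to compound 3 (1.00 log units; beyond the scatter), and compound 2, which also carries a bromine, gives 1000 nM. On that basis compound 4 is expected to move by a 6.7-fold lower number from compound 3 to compound 4 (0.82 log units; beyond the scatter) in this assay, with an estimated 1500 nM and a range from 400 nM to 6000 nM.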

Compound 4, concentration for 50% growth inhibition: 1000 nM
Compound 4: the middle estimate sits 1.5-fold (0.18 log units) above what was measured; the range from low to high includes it.
By their numbers in this assay, from the lowest: compounds 1, 2 and 4 (each within the scatter of the next); then compound 3.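

With a 10-fold lower number from compound 3 to compound 4 (1.00 log units; beyond the scatter) in this assay, 4-bromo-3-hydroxyphenyl restores what compound 3 gave up at this place on the chain. Hydroxy in place of nitro leaves no change at the digits printed from compound 2 to compound 4 (within the scatter) on that ring, and the whole ring swap leaves no change at the digits printed from compound 1 to compound 4 (within the scatter) as well, so this position accepts three different rings while 4-fluoro-3-methoxyphenyl alone stands apart. Nothing available explains this difference. From the compounds shown here alone, whether the methoxy or the fluorine sets compound 3 apart stays open. So does whether an amine or a carboxylic acid in place of the hydroxy would keep compound 4's level.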